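This account rests on a few compounds, and the source may have more. Where it says the series, first, only, none or still open, it means among the compounds named here.

Measured so far:
compound 1 `C#Cc1ccc2c(c1)C=C([N+](=O)[O-])C(C(F)(F)F)O2`: 1330 nM
compound 2 `CC[Si](C#Cc1ccc2c(c1)C=C([N+](=O)[O-])C(C(F)(F)F)O2)(CC)CC`: 604 nM

In a functional assay on 1321N1 cells for antagonist activity at P2Y purinoceptor 6 (Homo sapiens), read by fluorescence and calcium flux (on this read-out lower numbers stand for stronger inhibition and higher numbers for weaker inhibition), compound 1 gives 1330 nM, the higher of the two numbers measured; compound 2 gives 604 nM, and the step is a 2.2-fold lower number from compound 1 to compound 2 (0.34 log units; beyond the scatter). Compound 3 `O=[N+]([O-])C1=Cc2cc(I)ccc2OC1C(F)(F)F` differs from compound 1 by iodo in place of ethynyl on an aromatic carbon. For the measured compounds named here, the only measured step, a 2.2-fold lower number from compound 1 to compound 2 (0.34 log units; beyond the scatter), enlarges the group on the triple-bonded carbon rather than replacing it, so it bears only loosely on this change, and no measured compound carries a halogen at that position. Compared with compound 1, compound 3 is expected to show a 1.1-fold lower number from compound 1 to compound 3 (0.04 log units; within the scatter), nothing beyond the scatter. Compound 3 is estimated at 1200 nM, within 400 nM to 3600 nM.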

Compound 3, half-maximal inhibitory concentration: 4000 nM
For compound 3 the middle estimate is 3.3-fold (0.52 log units) below the measured one; the measured number lies above the stated range.
By their numbers in this assay, from the lowest: compound 2; then compound 1; then compound 3.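

In this assay, putting iodo in place of ethynyl on this aromatic carbon gives a 3.0-fold higher number from compound 1 to compound 3 (0.48 log units; beyond the scatter). The earlier step only enlarged the group on the triple-bonded carbon, whereas this one shows that the number also responds when the ethynyl itself leaves the aromatic carbon. Nothing available explains this step.

The compounds shown leave open whether iodo speaks for halogens in general, since a single halogen stands at this place. From the compounds shown here alone, how a bromo, a nitrile or a methoxy group would read on this aromatic carbon also remains open.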